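The compounds below may be only part of what the source reports. "The series", "measured", "known", "first", "only" and "open" are said of these compounds alone.

Measured in a physicochemical assay for lipophilicity, at pH 7.4; on this read-out higher numbers stand for higher lipophilicity and lower numbers for lower lipophilicity:
- compound 1 `CN(C)C(=O)C1CCN(c2cncnc2-c2ccc(F)cc2)CC1`: 1.9
- compound 2 `CN(C)C(=O)C1CCN(c2cnccc2-c2ccccn2)CC1`: 1.2
- compound 3 `CN(C)C(=O)C1CCN(c2cnccc2-n2cccn2)CC1`: 1.1

In this assay, compound 3 gives 1.1, which lies within the scatter of compound 2 at 1.2. Compound 1 stands clearly higher at 1.9, so compound 3 belongs with compound 2 at the low end of this small set.

The account now turns to compound 4 `Cc1cnn(-c2ccncc2N2CCC(C(=O)N(C)C)CC2)c1`, which differs from compound 3 by methyl in place of hydrogen on an aromatic carbon. In words, this is methyl in place of hydrogen on an aromatic carbon, taking 1H-pyrazol-1-yl to 4-methyl-1H-pyrazol-1-yl.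

Going by the values given here, only one measured step bears on this ring position: a number 0.10 log units lower from compound 2 to compound 3 (within the scatter), with 1H-pyrazol-1-yl in place of pyridin-2-yl on an aromatic carbon. That step brings in the unsubstituted ring but adds no methyl, so it sets no size for the present change. Among the compounds with values here, no measured pair shows this change directly, and the expectation rests on the structural change alone, starting from compound 3 at 1.1. A modest upward move is expected, with the expected step being a number 0.40 log units higher from compound 3 to compound 4 (beyond the scatter). The estimate for compound 4 is 1.5, with an expected range from 1.2 to 1.8.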

Compound 4, distribution coefficient: 1.6
For compound 4 the middle estimate is 0.10 log units below the measured one; the range from low to high includes it.
By their numbers in this assay, from the lowest: compounds 3 and 2 (each within the scatter of the next); then compounds 4 and 1 (each within the scatter of the next).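

In this assay, the step of a number 0.50 log units higher from compound 3 to compound 4 (beyond the scatter) gives the first measured size for methyl in place of hydrogen at this position, on an aromatic carbon of the five-membered ring, two ring bonds from the ring nitrogen. The earlier exchange of pyridin-2-yl for 1H-pyrazol-1-yl stayed within the scatter, whereas 4-methyl-1H-pyrazol-1-yl in place of pyridin-2-yl gives a number 0.40 log units higher from compound 2 to compound 4 (beyond the scatter) and so separates compound 4 from both of these compounds, showing that this one added carbon moves the read-out more than the earlier exchange of whole rings did. Nothing measured alongside this result accounts for the size of the step.

These compounds show a single substituent at a single position, so they leave open whether a longer chain such as ethyl, an amine or a carboxylic acid on the same carbon would move the number further, hold it or reverse it. They also leave open whether methyl on another carbon of the ring, or on the pyridin-2-yl ring of compound 2, would give a step of similar size.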